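Chlorine added to the benzyl group of compound 2

The source may hold more compounds than are shown below. What is called first, only, known or untested is meant among the compounds shown, and "the series" means these compounds.

Measured so far:
compound 1, `CC1=C(C(=O)Nc2ccc(F)cc2)C(c2ccc([N+](=O)[O-])cc2)N=C(SCc2ccccc2Cl)N1`: 12.4%
compound 2, `CC1=C(C(=O)Nc2ccc(Br)cc2)C(c2ccc(Cl)cc2Cl)N=C(SCc2ccccc2)N1`: 13.4%

Both compounds were tested in a functional assay on the whole organism (artery, strain albino) with Rattus norvegicus as the target, with a stated time of 180 min, at a dose of 10 mg/kg by the oral route; on this read-out higher numbers stand for more inhibition at the one dose given (going by the name of the read-out) and lower numbers for less inhibition. In this assay compound 1 gives 12.4% and compound 2 gives 13.4%. These two numbers sit within the usual scatter of each other, so neither compound can be placed above the other on this evidence; both show only modest inhibition at the dose given.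

Compound 3, `CC1=C(C(=O)Nc2ccc(Br)cc2)C(c2ccc(Cl)cc2Cl)N=C(SCc2ccccc2Cl)N1`, has not been measured yet. It differs from compound 2 in one place: chloro in place of hydrogen on an aromatic carbon. Compound 1 already carries the 2-chlorobenzyl group, though on a different pair of aryl rings, and its number is close to that of compound 2. Among the compounds with values here, no measured pair separates this change alone, so no step beyond the scatter is expected, and the estimated step of a number 0.4 percentage points lower from compound 2 to compound 3 (within the scatter) is taken as small. Compound 3 is therefore expected to give about 13%, within a range of 3% to 26%.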

Compound 3, a percentage reported as inhibition, in the whole organism at one dose (the size of the read-out at that dose, not a potency): 22.2%
Compound 3: middle estimate off by 9.2 percentage points, on the low side; low and high end bracket the measured number.
By their numbers in this assay, from the lowest: compounds 1, 2 and 3 (each within the scatter of the next).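

Within the data shown here, compound 2 and compound 3 differ in one place only, so the change from benzyl to 2-chlorobenzyl can now be read on its own for the first time. In this assay this change amounts to a number 8.8 percentage points higher from compound 2 to compound 3 (within the scatter), which gives no firm sign that adding the chloro at this position alters inhibition at the one oral dose tested. No measurement available here offers an explanation for this result.

The compounds shown leave open how this position on the benzyl group would respond to a different kind of group, such as a methoxy group, an amine or a carboxylic acid. They also leave open whether a chloro elsewhere on the same group would give a different reading, or whether a clearer difference would appear at other doses.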